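A Hydroxyethyl Group Gives Way to a Difluorobenzyl Group

The source may hold more compounds than are shown below. What is called first, only, known or untested is meant among the compounds shown, and "the series" means these compounds.

Compound 1, `Cc1cnc(Nc2ccnn2C)nc1-c1cc2n(c1)C(=O)N([C@H](CO)c1ccc(F)c(Cl)c1)C2`, was tested in a functional assay on COLO 205 cells (Homo sapiens) for antiproliferative activity, read by luminescence, with a stated time of 72 h (a lower number here means a stronger inhibitor, a higher number a weaker inhibitor), where compound 1 gives 94.9 nM. Its companion compound 2, `O=C1N([C@H](CO)c2cccc(Cl)c2)Cc2cc(-c3nc(NC4CCOCC4)ncc3Cl)cn21`, gives 104 nM in this assay, a number that sits within the usual scatter of the value for compound 1, so the two cannot be told apart on these data.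

Compound 3, `Cc1cnc(Nc2ccnn2C)nc1-c1cc2n(c1)C(=O)N(Cc1ccc(F)c(F)c1)C2`, has not yet been measured. It differs from compound 1 in one place: 3,4-difluorobenzyl in place of 1-(3-chloro-4-fluorophenyl)-2-hydroxyethyl on an amide-type nitrogen in a ring. Among the measured compounds shown here, no measured pair in this set shows what such a change does, so the expectation rests on the change itself: the group that leaves carries a hydrogen-bond donor and acceptor and a defined stereocentre, and the group that enters has none of these. The step of a 3.2-fold higher number from compound 1 to compound 3 (0.50 log units; beyond the scatter) is expected to be a modest weakening, beyond the scatter but not large. Compound 3 is therefore estimated at 300 nM in this assay, within a range from 80 nM to 1200 nM.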

Compound 3, half-maximal inhibitory concentration: 293 nM
Compound 3: middle estimate off by 1.0-fold (0.01 log units), on the high side; the range from low to high includes it.
By their numbers in this assay, from the lowest: compounds 1 and 2 (each within the scatter of the next); then compound 3.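

Replacing the group on this amide-type nitrogen gives a 3.1-fold higher number from compound 1 to compound 3 (0.49 log units; beyond the scatter) in this assay, so the position does respond to change, yet compound 3 remains active without the 2-hydroxyethyl branch or the defined stereocentre. This single step swaps several features at once: the hydrogen-bond donor and acceptor and the stereocentre leave, and a fluorine takes the place of the chlorine on the aromatic ring, so it cannot assign the weakening to any one of them. Nothing measured here explains the weakening.

Still open, on these data alone, is how much each feature contributes, which a plain 3-chloro-4-fluorobenzyl group would help to separate from the loss of the branch. It is also unknown whether an amine or a carboxylic acid at the end of the branch would serve as well as the hydroxyl.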